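This account rests on a few compounds, and the source may have more. Where it says the series, first, only, none or still open, it means among the compounds named here.

Compound 2 `Cc1ccccc1-c1nc(CN2CCC(C(=O)NCCCN3CCCCC3)CC2)c(C)o1` is the starting point in a physicochemical assay for solubility, in phosphate buffer, measured as kinetic solubility, at pH 7.4; on this read-out higher numbers stand for higher solubility and lower numbers for lower solubility. Compound 2 gives > 65 ug/mL, which is a limit of the assay and not a number. Compound 1 `Cc1oc(-c2ccccc2Cl)nc1CN1CCC(C(=O)NCCCN2C[C@H](C)C[C@H](C)C2)CC1` gives > 72 ug/mL, also a limit. Compound 3 `Cc1oc(-c2c(Cl)cccc2Cl)nc1CN1CCC(C(=O)NCCCN2C[C@H](C)C[C@H](C)C2)CC1` gives > 77 ug/mL, again a limit. Compound 2 therefore has no exact rank among these three. Compound 4 `Cc1ccccc1-c1nc(CN2CCC(C(=O)NCCCN3CC4CCCC(C4)C3)CC2)c(C)o1` differs from compound 2 in one place: a group of 9 heavy atoms (8 carbon, 1 nitrogen; one six-membered non-aromatic ring of carbon only, one six-membered non-aromatic ring with 1 hetero atom) in place of a group of 6 heavy atoms (5 carbon, 1 nitrogen; one six-membered non-aromatic ring with 1 hetero atom), on a saturated chain carbon, three bonds along the chain from an amide-type nitrogen. For the measured compounds named here, the one measured step, a step that the two limits leave unreadable from compound 1 to compound 3, involves a different change, and its size cannot be read, so no measured step bears on this one. The expected result is no step beyond the scatter in this assay, with an estimated step that the limit leaves unreadable from compound 2 to compound 4. For compound 4 the expected value is 70 ug/mL, with an estimated range from 35 ug/mL to 85 ug/mL.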

Compound 4, solubility: > 71 ug/mL
Compound 4: a limit, no number (the forecaster's own chance of this, stated with the estimate: 70%); middle value at least 1.0-fold (0.00 log units) from the limit.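

In this assay compound 2 and compound 4 each give only a limit of the assay and not a number, and the step between them cannot be read. Whether the two compounds truly differ in this assay stays open, as does the exact value of every compound shown.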